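This account rests on a few compounds, and the source may have more. Where it says the series, first, only, none or still open, it means among the compounds named here.

Measured compounds in the series:
compound 1, `CCCC[C@H](CC)C[C@]1(CC)C=C(CC)/C(=C/C(=O)OC)O1`
compound 2, `CCCCC(CC)CC(O)(/C=C(/CC)[C@@H](O)CC(=O)OC)CC`

In a functional assay on A549 cells (Homo sapiens) for cytotoxicity, read by MTT assay, with a stated time of 72 h (on this read-out lower numbers stand for stronger inhibition and higher numbers for weaker inhibition), compound 1 gives only a limit, > 100000 nM, and the assay reports no number for it. In this assay compound 2 gives 23600 nM. For the measured compounds named here, compound 1 and compound 2 differ in more than one place, so no single step between them is defined; their two values show only that compound 2 sits at a measured number while compound 1 sits at the limit of the assay, (the limit of > 100000 nM in this assay, at which 1 of the 2 values shown sits).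

Compound 3, `CC/C=C/[C@H](CC)C[C@]1(CC)C=C(CC)/C(=C/C(=O)OC)O1`, is not yet measured. It differs from compound 1 in one place: but-1-en-1-yl in place of butyl on a saturated chain carbon bound to two saturated chain carbons. Going by the values given here, no measured pair isolates a change of this kind, so there is no anchor for its size. A step of this sort is expected to stay within the usual scatter, with no clear direction, and the expected step from compound 1 to compound 3 in this assay is a number no higher from compound 1 to compound 3 (the limit leaves the size open). Compound 3 is therefore estimated at about 100000 nM, within a range from 30000 nM to 300000 nM, with a high chance that the assay again returns only a limit rather than a number.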

Compound 3, half-maximal inhibitory concentration: > 100000 nM
Compound 3 gave a limit, no number; the forecaster's own chance of this, stated with the estimate: 70%; the middle value lies on the limit itself.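

In this assay compound 3 gives > 100000 nM, which is a limit and not a number. Compound 1 also stands at a limit, so no step from compound 1 to compound 3 can be read: the limit of > 100000 nM in this assay, at which 2 of the 3 values shown sit.

As far as these compounds go, whether but-1-en-1-yl in place of butyl shifts the read-out at all, and in which direction, stays open.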